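The source may report more compounds than this note shows. Statements on the series, on what has been measured and on what is new or still open speak of the compounds shown alone.

Measured in a toxicity assay on NIH3T3 cells (Mus musculus) for cytotoxicity, read by resazurin assay; on this read-out higher numbers stand for an effect only at larger amounts of compound and lower numbers for an effect already at smaller amounts:
- compound 1 `COC(=O)c1ccc(NCc2cncn2Cc2ccc(Cl)cc2)cc1-c1ccccc1`: 25000 nM
- compound 2 `COC(=O)c1ccc(NCc2cncn2Cc2ccccc2)cc1-c1ccccc1`: > 1000 nM (a limit)
- compound 3 `COC(=O)c1ccc(NCc2cncn2Cc2ccc(N)cc2)cc1-c1ccccc1`: > 10000 nM (a limit)

Compound 3 stands only at a limit, > 10000 nM, so it offers no number to start from. the limit of > 10000 nM in this assay, at which 1 of the 3 values shown sits, is its place on the scale.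

The next compound is compound 4 `COC(=O)c1ccc(NCc2cncn2Cc2ccccc2Cl)cc1-c1ccccc1`. The change is 2-chlorophenyl in place of 4-aminophenyl on a saturated chain carbon bound to an aromatic nitrogen.

The nearest measured steps are a step that the limit leaves unreadable from compound 1 to compound 3 and a step that the limit leaves unreadable from compound 1 to compound 2. Neither gives a size to carry over. Within the data shown here, compound 1 holds the only number, 25000 nM, and it also carries a chloro group on an aromatic carbon, so the expectation leans on it.

The expected step, with no firm direction, is a step that the limit leaves unreadable from compound 3 to compound 4. Compound 4 is estimated at 20000 nM, with an expected range of 8000 nM to 50000 nM.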

Compound 4, half-maximal effective concentration: 10000 nM
Compound 4: the middle estimate sits 2.0-fold (0.30 log units) above what was measured, and the stated range covers the measured number.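

Compound 4 gives the series its first readable step in this assay: a 2.5-fold lower number from compound 1 to compound 4 (0.40 log units; beyond the scatter), a modest change. The earlier compounds shown here showed no readable step, and this one shows that the chloro compounds 1 and 4, which differ only in 4-chlorobenzyl against 2-chlorobenzyl, can be told apart on this read-out. The step that reaches compound 4 from compound 2 cannot be read. The step that starts from a limit of the assay, 4-aminobenzyl to 2-chlorobenzyl, shows only this: a number no higher from compound 3 to compound 4 (the limit leaves the size open). Nothing at hand accounts for the size of the step.

From the compounds shown here alone, whether a 3-chlorophenyl or 2-methylphenyl group at this place would read like compound 4 stays open. So does the effect of a carboxylic acid in place of the methyl ester of the shared core.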